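The source may report more compounds than this note shows. Statements on the series, on what has been measured and on what is new or still open speak of the compounds shown alone.

Measured compounds:
Compound 1, `COc1ccc(C(=O)O)cc1-c1cccc(COc2ccc3c(c2)CN(C2CCCC2)C3=O)c1`, gives 80 nM in an assay on HEK293 cells for positive allosteric modulation of metabotropic glutamate receptor 2 (Rattus norvegicus), read by thallium flux; a lower number here means that less compound is needed, a higher number that more compound is needed for the effect.
Compound 2, `O=C(O)c1cc(-c2cccc(COc3ccc4c(c3)CN(C3CCCC3)C4=O)c2)ccc1O`, gives 20 nM in this assay.
Compound 3, `O=C(O)c1cc(-c2cccc(COc3ccc4c(=O)n(C5CCC5)sc4c3)c2)ccc1Cl`, gives 580 nM in this assay.

Among the three measured compounds, compound 2 holds the lowest number in this assay; compound 1 is nearest to it, and compound 3, built on a different core, lies furthest away. For the measured compounds named here, the only single-place step among the measured set is a 4.0-fold lower number from compound 1 to compound 2 (0.60 log units; beyond the scatter), which shows that the substitution pattern on the outer aromatic ring moves the read-out by a modest but real amount.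

Compound 4, `O=C(O)c1cc(F)cc(-c2cccc(COc3ccc4c(c3)CN(C3CCCC3)C4=O)c2)c1`, differs from compound 2 in exactly that ring: 3-carboxy-5-fluorophenyl in place of 3-carboxy-4-hydroxyphenyl on an aromatic carbon. Going by the values given here, no measured pair mirrors this exchange of a hydroxyl for a fluorine with the carboxylic acid kept, so the expectation rests on the one step above. Since that step shows the ring pattern matters by a modest margin, a change of similar size is expected here, and the loss of one hydrogen-bond donor and one acceptor leans the expectation toward a higher number. Compound 4 is therefore expected to give 60 nM in this assay, with a range from 20 nM to 200 nM, which corresponds to an expected step of a 3.0-fold higher number from compound 2 to compound 4 (0.48 log units; beyond the scatter).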

Compound 4, half-maximal effective concentration: 130 nM
Compound 4: the middle estimate sits 2.2-fold (0.34 log units) below what was measured, and the stated range covers the measured number.
By their numbers in this assay, from the lowest: compound 2; then compounds 1 and 4 (each within the scatter of the next); then compound 3.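

In this assay, replacing 3-carboxy-4-hydroxyphenyl with 3-carboxy-5-fluorophenyl gives a 6.5-fold higher number from compound 2 to compound 4 (0.81 log units; beyond the scatter), so the carboxylic acid on this ring does not by itself secure the low number of compound 2, and the rest of the ring's substitution matters at this position. The other new comparison, a 1.6-fold higher number from compound 1 to compound 4 (0.21 log units; within the scatter), means that 5-carboxy-2-methoxyphenyl and 3-carboxy-5-fluorophenyl cannot be told apart here, while 3-carboxy-4-hydroxyphenyl stands apart from both on the shared core. Nothing available explains why the hydroxyl-bearing ring differs from the other two.

Because the hydroxyl leaves and the fluorine enters in a single exchange, the compounds shown do not separate the contribution of one from that of the other, and a ring carrying the carboxylic acid alone, or one with an amine or a methyl ether in place of the hydroxyl, would be needed to do so. They also leave open whether the same order of these rings would hold on the core of compound 3.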